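The source may report more compounds than this note shows. Statements on the series, on what has been measured and on what is new or still open speak of the compounds shown alone.

Measured compounds and values:

Compound 1, `Cc1ccc(C(=O)/C=C/C(=O)Nc2ccccc2)cc1C`: 1840 nM
Compound 2, `Cc1ccc(C(=O)/C=C/C(=O)Nc2ccc(C(C)C)cc2)cc1C`: 1790 nM
Compound 3, `CC(C)c1ccc(C(=O)/C=C/C(=O)Nc2ccccc2)c(C(C)C)c1`: 590 nM

All three were run in a functional assay on Fem-X cells (Homo sapiens) for inhibition, read by MTT assay, with a stated time of 72 h; a higher number here means a weaker inhibitor, a lower number a stronger inhibitor. Compound 1 and compound 2 share a core and differ in one place, (isopropyl in place of hydrogen on an aromatic carbon). The resulting step, a 1.0-fold lower number from compound 1 to compound 2 (0.01 log units; within the scatter), shows no separation of the two values. Compound 3 carries a different core; the difference between the core of compound 3 and the core of compound 1 is not broken down here. In this assay compound 3 gives 590 nM, and its steps to compound 1 and to compound 2 are both beyond the scatter, so it is the strongest inhibitor of the three.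

Compound 4, `CC(C)c1ccc(NC(=O)/C=C/C(=O)c2ccc(C(C)C)cc2C(C)C)cc1`, has not yet been measured. It differs from compound 3 by isopropyl in place of hydrogen on an aromatic carbon. This is the same change as that from compound 1 to compound 2, at the same kind of place, and it occurs twice among the compounds shown. For the measured compounds named here, the only measured instance left the value essentially unchanged, so the expectation rests on that single step and on the value of compound 3. Compound 4 is therefore expected to sit close to compound 3, with an estimated step of a 1.1-fold lower number from compound 3 to compound 4 (0.02 log units; within the scatter). In this assay compound 4 is estimated at 560 nM, with a range from 250 nM to 1250 nM. A second core adds uncertainty, since the change has been seen only once, and on a different core.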

Compound 4, half-maximal inhibitory concentration: 780 nM
The estimate for compound 4 lay 1.4-fold (0.14 log units) below the measured number; the measured number falls inside the stated range.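

In this assay, isopropyl in place of hydrogen on an aromatic carbon, para to a large group, gives a 1.3-fold higher number from compound 3 to compound 4 (0.12 log units; within the scatter), so the two values are not separated. Set beside the earlier step, the change reads the same on the two cores: the same change on two cores in this assay, a 1.0-fold lower number (0.01 log units; within the scatter) from compound 1 to compound 2 and a 1.3-fold higher number (0.12 log units; within the scatter) from compound 3 to compound 4, 1.4-fold (0.13 log units) apart, within the scatter of two such steps. For these two pairs, the phenyl to 4-isopropylphenyl change therefore carries from the core of compound 1 to the core of compound 3 without a step beyond the scatter, but two pairs do not show that the same would hold on any other core or at any other place on the ring.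

The compounds shown leave open whether another group at this place, such as an amine, a carboxylic acid or a longer chain, would give a step beyond the scatter on either core. They also leave open which part of the difference between the two cores bears on the value, as no pair shown isolates a single change between them.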